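This account rests on a few compounds, and the source may have more. Where it says the series, first, only, none or still open, it means among the compounds named here.

In a physicochemical assay for lipophilicity, measured as octanol-water partition, at pH 7.4 (on this read-out higher numbers stand for higher lipophilicity and lower numbers for lower lipophilicity), compound 1 `Cc1ccc(Cn2c(=O)[nH]c3c(N)nc(C(F)(F)F)cc32)nn1` gives 1.1 and compound 2 `Cc1cccc(Cn2c(=O)[nH]c3c(N)nc(C(F)(F)F)cc32)n1` gives 2.3 as the higher of the two numbers. Among the compounds with values here, the one measured step, a number 1.20 log units higher from compound 1 to compound 2 (beyond the scatter) with 6-methylpyridin-2-yl in place of 6-methylpyridazin-3-yl, is large and beyond the scatter. Compound 3 `Cc1nc(Cn2c(=O)[nH]c3c(N)nc(C(F)(F)F)cc32)cs1` instead has 2-methyl-1,3-thiazol-4-yl in place of 6-methylpyridin-2-yl, a swap counted as 2-methyl-1,3-thiazol-4-yl in place of 6-methylpyridin-2-yl on a saturated chain carbon bound to an aromatic nitrogen and made on a saturated chain carbon bound to an aromatic nitrogen. That measured step involves a different swap, so it is only a loose guide. A small drop is expected, a number 0.20 log units lower from compound 2 to compound 3 (within the scatter) in this assay and probably within the scatter. The estimate for compound 3 is 2.1 with an expected range from 1.6 to 2.6 on this scale.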

Compound 3, distribution coefficient: 2.3
Compound 3: the middle estimate sits 0.20 log units below what was measured; the range from low to high includes it.
By their numbers in this assay, from the lowest: compound 1; then compounds 2 and 3 (each within the scatter of the next).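

In this assay the swap to 2-methyl-1,3-thiazol-4-yl from 6-methylpyridin-2-yl shows no change at the digits printed from compound 2 to compound 3 (within the scatter) and so a five-membered ring can take the place of a six-membered one on this saturated chain carbon. Against 6-methylpyridazin-3-yl the same thiazole shows a number 1.20 log units higher from compound 1 to compound 3 (beyond the scatter) and this leaves compound 1 alone at the low end of the three. Nothing available explains these numbers. On these data alone, what a ring carrying an amine or a carboxylic acid in place of the methyl would give at this position remains open.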